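Piperazine nitrogen substituent series: aryl replacing alkyl

The source may hold more compounds than are shown below. What is called first, only, known or untested is meant among the compounds shown, and "the series" means these compounds.

Three measured compounds share one core and differ only in the group on an amine nitrogen in a ring. Compound 1 `Cc1cccc2sc(NC(=O)CCN3CCN(C(C)(C)C)CC3)nc12` gives 200 nM in an assay on membranes from liver for displacement of a labelled ligand from Sigma intracellular receptor 2 (Rattus norvegicus), read by scintillation counting, with a stated time of 120 min; a higher number here means a weaker inhibitor, a lower number a stronger inhibitor. Compound 2 `CCCCN1CCN(CCC(=O)Nc2nc3c(C)cccc3s2)CC1` gives 1200 nM in this assay, the highest number of the three. Compound 3 `Cc1cccc2sc(NC(=O)CCN3CCN(CC4CCCCC4)CC3)nc12` gives 519 nM in this assay. The step of a 6.0-fold higher number from compound 1 to compound 2 (0.78 log units; beyond the scatter) and the step of a 2.3-fold lower number from compound 2 to compound 3 (0.36 log units; beyond the scatter) both involve compound 2 and the same position; the step of a 2.6-fold higher number from compound 1 to compound 3 (0.41 log units; beyond the scatter) completes the set. Both steps away from compound 2 lower the number.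

Compound 4 `Cc1cccc2sc(NC(=O)CCN3CCN(c4ccncc4)CC3)nc12` carries the change (pyridin-4-yl in place of butyl on an amine nitrogen in a ring). Going by the values given here, no measured step puts an aromatic ring on this nitrogen; the bearing steps replace one saturated group with another, and both are modest. They show that this position can move the number by a modest amount in either direction, but give no direct guide for an aromatic ring.

Given the spread seen around compound 2, compound 4 is expected near the higher end of the measured range, with the step of a 1.7-fold higher number from compound 2 to compound 4 (0.22 log units; within the scatter) expected to be modest and uncertain in direction. Compound 4 is estimated at 2000 nM, within a range from 500 nM to 8000 nM.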

Compound 4, inhibition constant: 1700 nM
Compound 4: middle estimate off by 1.2-fold (0.07 log units), on the high side; the measured number falls inside the stated range.
By their numbers in this assay, from the lowest: compound 1; then compound 3; then compounds 2 and 4 (each within the scatter of the next).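

In this assay, the first aromatic ring on this amine nitrogen cannot be told apart from butyl: a 1.4-fold higher number from compound 2 to compound 4 (0.15 log units; within the scatter). Going by these compounds alone, the same group reads differently against the other saturated groups, with a 3.3-fold higher number from compound 3 to compound 4 (0.52 log units; beyond the scatter) for cyclohexylmethyl and, the largest step at this position so far, an 8.5-fold higher number from compound 1 to compound 4 (0.93 log units; beyond the scatter) for tert-butyl. The lowest number in the set remains that of compound 1 at 200 nM, whose steps to the other three compounds all lie beyond the scatter, so pyridin-4-yl offers no route to a lower number at this position.

The data shown offer nothing that accounts for this ordering of the four groups. Open, going by these compounds, is how a phenyl ring, with carbon in place of the pyridine ring nitrogen, or a smaller branched group such as isopropyl would read on this amine nitrogen: the first would separate the aromatic ring from its nitrogen, and the second would test whether branching goes with the lower number of compound 1.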